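This account rests on a few compounds, and the source may have more. Where it says the series, first, only, none or still open, it means among the compounds named here.

Compound 1 `COc1ccc2[nH]c(=O)c(-c3nc4cc(C)c(C)cc4[nH]3)cc2c1` in an ADME assay on L02 cells (Homo sapiens) for cytotoxicity, read by MTT assay, with a stated time of 48 h (a higher number here means a weaker inhibitor, a lower number a stronger inhibitor), gives only a limit of the assay, > 100000 nM. Compound 2 `Cc1ccc2[nH]c(=O)c(-c3nc4ccccc4[nH]3)cc2c1` likewise gives only a limit, > 100000 nM. Compound 3 `COc1ccc2[nH]c(=O)c(-c3nc4ccccc4[nH]3)cc2c1` also gives only a limit, > 100000 nM. Among the measured compounds shown here, the one measured step that bears on the change considered here, a step that the two limits leave unreadable from compound 2 to compound 3, cannot be read, since both of its ends are limits. Compound 4 `Cc1ccc2[nH]c(=O)c(-c3nc4cc(C)c(C)cc4[nH]3)cc2c1` differs from compound 1 by methyl in place of methoxy on an aromatic carbon. Every value shown so far sits at the limit of > 100000 nM in this assay, at which 3 of the 3 values shown sit, so no step beyond the scatter is expected for compound 4 in this assay, and a limit rather than a number is the likely report. The estimate for compound 4 is 100000 nM, with a range from 50000 nM to 300000 nM. The expected step of a number no higher from compound 1 to compound 4 (the limit leaves the size open) is accordingly none beyond the scatter.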

Compound 4, half-maximal inhibitory concentration: > 100000 nM
Compound 4 gave a limit, no number; the forecaster's own chance of this, stated with the estimate: 90%; the middle value sits exactly at the limit.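

Compound 1 and compound 4 both give only a limit of the assay, so no step can be read between them. The compounds shown leave open whether any change on the shared core alters cytotoxicity: the limit of > 100000 nM in this assay, at which 4 of the 4 values shown sit.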